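Hexyl to cyclohexyl on the aromatic nitrogen

The source may report more compounds than this note shows. Statements on the series, on what has been measured and on what is new or still open speak of the compounds shown alone.

Measured so far in a functional assay on EOL1 cells (Homo sapiens) for inhibition, read by fluorescence, with a stated time of 72 h (on this read-out lower numbers stand for stronger inhibition of growth and higher numbers for weaker inhibition of growth), for three compounds:
- compound 1 `COc1ccc(Nc2nc(N[C@H]3CC[C@H](N)CC3)nc3c2ncn3CCC(C)C)c(OC)c1` gives 630 nM here
- compound 2 `CC(C)CCn1cnc2c(Nc3ccc(Cl)cc3)nc(N[C@H]3CC[C@H](N)CC3)nc21` gives 90 nM here
- compound 3 `CCCCCCn1cnc2c(Nc3ccc(Cl)cc3)nc(N[C@H]3CC[C@H](N)CC3)nc21` gives 440 nM here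

Compound 3 lies within the scatter of compound 1, while compound 2 holds the lowest number, beyond the scatter of both. The next compound, compound 4 `N[C@H]1CC[C@H](Nc2nc(Nc3ccc(Cl)cc3)c3ncn(C4CCCCC4)c3n2)CC1`, carries cyclohexyl in place of hexyl on an aromatic nitrogen and so has cyclohexyl in place of hexyl on an aromatic nitrogen. For the measured compounds named here, the one measured change in this chain is a 4.9-fold higher number from compound 2 to compound 3 (0.69 log units; beyond the scatter) in this assay and it is modest. The other step, a 7.0-fold lower number from compound 1 to compound 2 (0.85 log units; beyond the scatter), came from the 4-chlorophenyl exchange and bears little here, since compound 4 keeps that group. No ring on this nitrogen has been measured, so the direction is tentative. The expected change is a 2.6-fold lower number from compound 3 to compound 4 (0.41 log units; beyond the scatter) and it is estimated as modest, at most about the size of the chain step. For compound 4 the estimated value is 170 nM with an expected range from 50 nM to 550 nM in this read-out.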

Compound 4, concentration for 50% growth inhibition: 140 nM
Compound 4: middle estimate off by 1.2-fold (0.08 log units), on the high side, and the stated range covers the measured number.
By their numbers in this assay, from the lowest: compounds 2 and 4 (each within the scatter of the next); then compounds 3 and 1 (each within the scatter of the next).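

In this assay, a ring on the aromatic nitrogen is tolerated: with hexyl folded into cyclohexyl, the series shows a 3.1-fold lower number from compound 3 to compound 4 (0.50 log units; beyond the scatter), so the number at this position depends on the shape of the group and not only on its carbon count. Cyclohexyl against isopentyl gives a 1.6-fold higher number from compound 2 to compound 4 (0.19 log units; within the scatter), so these two groups cannot be told apart here, and among the compounds with 4-chlorophenyl, only hexyl stands apart, with the higher number. No supporting data bear on the reason for this difference.

Going by these compounds, it remains open how cyclopentyl, phenyl or a cyclohexyl ring carrying an amine would behave on this nitrogen. Also open, on these data alone, is whether cyclohexyl gives a similar result alongside 2,4-dimethoxyphenyl in place of 4-chlorophenyl.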